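Pyrrole methyl deletion in a Boc-protected indolyl series

This account rests on a few compounds, and the source may have more. Where it says the series, first, only, none or still open, it means among the compounds named here.

Of the compounds shown here, two carry a measured value so far. Compound 1 `COC1=CC(c2cc3ccccc3[nH]2)=N/C1=C\c1ccc(-c2cc3ccccc3[nH]2)[nH]1` and compound 2 `COC1=CC(c2cc3ccccc3n2C(=O)OC(C)(C)C)=N/C1=C\c1[nH]c(C)cc1C` share the methoxy-bearing core and differ at both ends of it. In a functional assay on PLC5 cells (Homo sapiens) for cytotoxicity, read by MTT assay (a higher number here means a weaker inhibitor, a lower number a stronger inhibitor), compound 1 gives 15900 nM. In this assay compound 2 gives 28400 nM, the higher of the two figures on hand, but compound 1 sits within the usual scatter of it, so the two are not separated by the data.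

Compound 3 `COC1=CC(c2cc3ccccc3n2C(=O)OC(C)(C)C)=N/C1=C\c1ccc[nH]1` is not yet measured. It differs from compound 2 in one place: 1H-pyrrol-2-yl in place of 3,5-dimethyl-1H-pyrrol-2-yl on a double-bonded chain carbon bound to a double-bonded ring carbon. Among the compounds with values here, no pair of measured compounds separated by a single change exists, so no measured step can be carried over to this one.

Within the data shown here, with both measured numbers lying close together and no step on record for a change of this kind, the step from compound 2 to compound 3 in this assay is expected to stay within the scatter, a 1.1-fold higher number from compound 2 to compound 3 (0.02 log units; within the scatter), with no clear direction. Compound 3 is therefore estimated at 30000 nM in this assay, within a range from 10000 nM to 90000 nM.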

Compound 3, half-maximal inhibitory concentration: > 40000 nM
Compound 3: no number, only a limit (the forecaster's own chance of this, stated with the estimate: 15%); at least 1.3-fold (0.12 log units) between middle value and limit.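

Within the data shown here, the first single-change step is 1H-pyrrol-2-yl in place of 3,5-dimethyl-1H-pyrrol-2-yl on a double-bonded chain carbon bound to a double-bonded ring carbon: an at least 1.4-fold higher number from compound 2 to compound 3 (0.14 log units; that floor lies within the scatter) in this assay, and only a floor is on record for it. Compound 3 gives > 40000 nM in this assay, which is a limit of the assay and not a number. Losing both methyl groups at this position therefore brings no sign of a lower number, but the floor alone does not fix the size of the step, and the reading rests on a single limit: the limit of > 40000 nM in this assay, at which 1 of the 3 values shown sits.

The compounds shown leave open how far the true figure for compound 3 lies past its limit, and whether the same change would read alike on the other end carried by compound 1. They also leave open what a carboxylic acid or an aminomethyl group would do on the pyrrole ring at this position, in place of the two methyl groups.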